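Pyridin-2-yl in place of a piperidine: solubility outlook

A few compounds are considered here, and "the series" means these few. Any claim that something is new, unique, unknown or untested is made for them only; others in the source may bear on it.

Two compounds have been measured in a physicochemical assay for solubility, in phosphate buffer, at pH 7.4; on this read-out higher numbers stand for higher solubility and lower numbers for lower solubility:

Compound 1, `OCC1CCN(c2cccnc2OC2CN(c3ccc4ccccc4n3)C2)CC1`, gives 189000 nM.
Compound 2, `COCC1CCN(c2nccnc2OC2CN(c3ccc4ccccc4n3)C2)CC1`, gives 53000 nM.

Compound 2 holds the lower of the two numbers; compound 1 sits higher, and that gap lies beyond the usual scatter. Compound 3, `c1ccc(-c2nccnc2OC2CN(c3ccc4ccccc4n3)C2)nc1`, has not been measured. It differs from compound 2 in one place: pyridin-2-yl in place of 4-(methoxymethyl)piperidin-1-yl on an aromatic carbon. Among the measured compounds shown here, no two measured compounds differ in exactly this way, so the size of the step has no direct precedent. The expected step is a 3.5-fold lower number from compound 2 to compound 3 (0.55 log units; beyond the scatter), downward and beyond the scatter. Compound 3 is therefore estimated at 15000 nM, within a range from 4000 nM to 50000 nM.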

Compound 3, solubility: 349000 nM
Compound 3: the middle estimate sits 23-fold (1.37 log units) below what was measured, outside the stated range (above it).
By their numbers in this assay, from the lowest: compound 2; then compounds 1 and 3 (each within the scatter of the next).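

At this aromatic carbon next to the ring nitrogen, this assay shows a 6.6-fold higher number from compound 2 to compound 3 (0.82 log units; beyond the scatter) when pyridin-2-yl replaces 4-(methoxymethyl)piperidin-1-yl. Thus, in this pair, the six-membered aromatic ring carries the higher number, although one pair sets no general rule. Nothing available explains the direction of this step. Still open, going by these compounds, is how a phenyl group or a morpholin-4-yl group would read at this position. Also open, on these data alone, is whether the same exchange would give a similar step on the core of compound 1.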